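Cytotoxicity notes: from compound 3 to compound 4

The compounds below may be only part of what the source reports. "The series", "measured", "known", "first", "only" and "open" are said of these compounds alone.

Measured in an ADME assay on MDBK cells (Bos taurus) for cytotoxicity, read by MTT assay, with a stated time of 96 h (on this read-out lower numbers stand for higher toxicity in this test and higher numbers for lower toxicity in this test), each value being a limit:
- compound 1 `C/C(=N\NC(N)=O)c1ccc2[nH]c(-c3ccc(C(F)(F)F)cc3)nc2c1`: > 100000 nM
- compound 2 `CC(=O)c1ccc2c(c1)nc(-c1ccccc1)n2C1CCCCC1`: > 100000 nM
- compound 3 `C/C(=N\NC(N)=O)c1ccc2c(c1)nc(-c1ccccc1)n2C1CCCCC1`: > 100000 nM

Compound 3 has no number on this read-out, only the limit > 100000 nM. The other two compounds offer no numerical comparison either: the limit of > 100000 nM in this assay, at which 3 of the 3 values shown sit.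

Compound 4 `C/C(=N\NC(N)=O)c1ccc2c(c1)nc(-c1ccc(C(F)(F)F)cc1)n2C1CCCCC1` differs from compound 3 by trifluoromethyl in place of hydrogen on an aromatic carbon, on an aromatic carbon of a six-membered aromatic ring of carbon only, para to a large group. For the measured compounds named here, no measured step makes this change. Going by the values given here, the one measured step, a step that the two limits leave unreadable from compound 2 to compound 3, gives no size to carry over.

Compound 1, which already has the 4-(trifluoromethyl)phenyl group, also sits at the limit > 100000 nM.

No step beyond the scatter is therefore expected in this assay, and a report at the limit is the likeliest outcome. The expected change is an at least 1.1-fold lower number from compound 3 to compound 4 (0.04 log units; that floor lies within the scatter). For compound 4 the estimate is 90000 nM, with an expected range of 40000 nM to 100000 nM.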

Compound 4, half-maximal cytotoxic concentration: > 100000 nM
Compound 4: a limit, no number (the forecaster's own chance of this, stated with the estimate: 75%); middle value at least 1.1-fold (0.04 log units) away from the limit.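

No step can be read from compound 3 to compound 4, or from compound 1 to compound 4, in this assay, as each pair holds only limits and no numbers: the limit of > 100000 nM in this assay, at which 4 of the 4 values shown sit.

The compounds shown leave open at what concentration any of them would register in this assay, and whether the trifluoromethyl or cyclohexyl change alters that concentration.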